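The source may hold more compounds than are shown below. What is called first, only, known or untested is meant among the compounds shown, and "the series" means these compounds.

In a functional assay on CCRF-CEM cells (Homo sapiens) for antiproliferative activity, read by cell counting, with a stated time of 2 days (on this read-out higher numbers stand for weaker inhibition and lower numbers for stronger inhibition), two compounds on a shared core have been measured so far. Compound 1 (`COc1cccc(Nc2nc(N)c(C(=O)c3ccccc3)s2)c1`) gives 2900 nM and compound 2 (`COc1cc(C(=O)c2sc(Nc3ccccc3)nc2N)cc(OC)c1OC`) gives 9.4 nM on this read-out. Compound 2 therefore holds the lower of the two numbers, and its gap to compound 1 lies beyond the scatter. That pair differs in more than one place, so no single change can be read from it.

Compound 3 (`COc1ccc(C(=O)c2sc(Nc3ccccc3)nc2N)cc1OC`) has yet to be measured in this assay. It departs from compound 2 in one place: hydrogen in place of methoxy on an aromatic carbon (hydrogen in place of methoxy on an aromatic carbon, ortho to a methoxy group). Within the data shown here, no measured step covers this change, so the expectation rests on thin evidence. Among the measured compounds shown here, the only guide is compound 1 at 2900 nM as a sign of how high a number on this core can lie with fewer methoxy groups. A rise beyond the scatter, toward weaker inhibition, is expected. The expected change is a 32-fold higher number from compound 2 to compound 3 (1.50 log units; beyond the scatter) in that direction. Compound 3 is estimated at 300 nM with an expected range from 40 nM to 2500 nM in this assay.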

Compound 3, half-maximal inhibitory concentration: 6900 nM
Estimate against measurement, compound 3: 23-fold (1.36 log units) below; measured number outside the range, above it.
By their numbers in this assay, from the lowest: compound 2; then compound 1; then compound 3.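

In this assay, among these compounds, hydrogen in place of methoxy gives a 730-fold higher number from compound 2 to compound 3 (2.87 log units; beyond the scatter), the first change in one place on the shared core and one that lies well beyond the scatter. It shows that this single methoxy group, on an aromatic carbon, ortho to a methoxy group and meta to a large group, matters greatly for the low number of compound 2: compound 3 keeps the other two methoxy groups on that ring, yet they do not hold the number down without it. The pair shows that the step is large but not what lies behind it, and nothing measured on these compounds bears on its cause.

Going by these compounds, whether the position needs methoxy itself remains open, since a hydroxyl, an ethoxy group, a fluorine or an amine at the same carbon would separate that group from other replacements. The compounds shown also leave open how much each of the two remaining methoxy groups adds on its own, as this is the only step on the ring that can be read.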